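Chloro for Fluoro: One Halogen Swap on Compound 1

The compounds below may be only part of what the source reports. "The series", "measured", "known", "first", "only" and "open" are said of these compounds alone.

Three compounds have been measured in a functional assay on THP-1 cells (Homo sapiens) for inhibition, read by sulforhodamine B assay, with a stated time of 48 h, tested at 50 uM; a lower number here means less inhibition of growth, a higher number more inhibition of growth at the concentration tested:

compound 1, `O=C1C(=O)N(CCCn2cc(COc3cc(=O)oc4ccccc34)nn2)c2ccc(F)cc21`, 86%
compound 2, `COc1ccc2c(c1)C(=O)C(=O)N2CCCCCn1cc(COc2cc(=O)oc3ccccc23)nn1`, 30%
compound 3, `O=C1C(=O)N(CCCCn2cc(COc3cc(=O)oc4ccccc34)nn2)c2ccc(I)cc21`, 59%

Among these three, compound 1 stands highest. Its nearest neighbour is compound 3, whose number lies lower by a gap beyond the usual scatter, and compound 2 lies further below still, also beyond the scatter. Within the data shown here, no pair of these measured compounds differs in a single place, so none of the gaps between them can be traced to one structural change; compound 1 and compound 3 differ in both the halogen and the chain length, and compound 2 differs in more places again.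

The compound under consideration is compound 4, `O=C1C(=O)N(CCCn2cc(COc3cc(=O)oc4ccccc34)nn2)c2ccc(Cl)cc21`. It is compound 1 with one exchange: chloro in place of fluoro on an aromatic carbon. Everything else, the chain and the remainder of the shared core, is retained.

Nothing measured here isolates a halogen exchange at this place. Given that, the expectation for compound 4 rests mainly on compound 1 and on the smallness of the change. The step of a number 6 percentage points lower from compound 1 to compound 4 (within the scatter) is expected to be small, most likely within the scatter, with the direction uncertain. Compound 4 is therefore estimated at 80% in this assay, within a range from 60% to 95%.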

Compound 4, percent growth inhibition at one concentration: 78%
Estimate against measurement, compound 4: 2 percentage points above; the range from low to high includes it.
By their numbers in this assay, from the lowest: compound 2; then compound 3; then compounds 4 and 1 (each within the scatter of the next).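

Among these compounds, with the chain and the rest of the shared core held constant, the exchange of fluoro for chloro gives the first comparison in this set that isolates one change. In this assay, the step is a number 8 percentage points lower from compound 1 to compound 4 (within the scatter), so on this aromatic carbon, meta to a fused ring and para to a fused ring, these two halogens cannot be told apart at the single concentration tested. Nothing available here explains why the two compounds read alike.

The compounds shown leave open how an amine, a carboxylic acid or a nitrile on this same aromatic carbon would read, and whether a plain hydrogen there would give a number close to those of the two halogen compounds. They also leave open how much the chain contributes with the halogen held fixed, since the compounds shown offer no pair that differs in the chain alone.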